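The compounds below may be only part of what the source reports. "The series", "measured", "known", "first", "only" and "open" are said of these compounds alone.

Compounds measured so far:
- compound 1, `CCOc1ccc(-c2ccc3ncn(-c4cc(OC)c(OC)c(OC)c4)c3c2)cc1`, 2970 nM
- compound 2, `COc1cc(-n2cnc3ccc(-c4cc(F)ccc4F)cc32)cc(OC)c1OC`, 6590 nM

Both were tested in a functional assay on SGC-7901 cells (Homo sapiens) for antiproliferative activity, read by MTT assay, with a stated time of 72 h; a higher number here means a weaker inhibitor, a lower number a stronger inhibitor. Within the data shown here, compound 1 has the lower of the two numbers; the only other measured compound, compound 2, sits a 2.2-fold higher number from compound 1 to compound 2 (0.35 log units; beyond the scatter) away, a change brought by 2,5-difluorophenyl in place of 4-ethoxyphenyl on an aromatic carbon.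

The compound considered next is compound 3, `COc1ccc(-c2ccc3ncn(-c4cc(OC)c(OC)c(OC)c4)c3c2)cc1`. It differs from compound 1 only in one spot: hydrogen in place of methyl on a saturated chain carbon bound to an oxygen on an aromatic ring. Among the measured compounds shown here, no measured pair tells directly what trimming an ethoxy group to a methoxy group does here; the single known step concerns a different group altogether. Such a small change is expected to move the number little, if at all, so the step in this assay is estimated at a 1.0-fold higher number from compound 1 to compound 3 (0.00 log units; within the scatter), not beyond the usual scatter. For compound 3 the expected value is 3000 nM, within 1500 nM to 6000 nM.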

Compound 3, half-maximal inhibitory concentration: 82 nM
Compound 3: middle estimate off by 37-fold (1.56 log units), on the high side; the whole stated range lies above it.
By their numbers in this assay, from the lowest: compound 3; then compound 1; then compound 2.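

Trimming the ethoxy group to a methoxy group removes only one carbon, yet it gives a 36-fold lower number from compound 1 to compound 3 (1.56 log units; beyond the scatter) in this assay, so a single methyl on a saturated chain carbon bound to an oxygen on an aromatic ring can matter a great deal in this series. The earlier pair showed only a modest shift between two quite different aryl groups, whereas an 80-fold lower number from compound 2 to compound 3 (1.91 log units; beyond the scatter) with 4-methoxyphenyl in place of 2,5-difluorophenyl shows how much the choice of group on this aromatic carbon can matter. Nothing available explains why so small an edit has so large an effect.

As far as these compounds go, it remains open what a hydroxyl group, a propoxy group or an amine would do in place of the methoxy group. From the compounds shown here alone, whether the gain from the shorter chain holds beyond this assay also remains open.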